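Replacing the Acylguanidine Arm with a Dimethylurea

The source may report more compounds than this note shows. Statements on the series, on what has been measured and on what is new or still open speak of the compounds shown alone.

Among the compounds with values here, compound 2 `N=C(N)NC(=O)C[C@@H]1CCCc2cc(S(=O)(=O)c3cccc(F)c3)ccc21` gives 0.631 nM in an assay on isolated protein for displacement of a labelled ligand from 5-hydroxytryptamine receptor 6 (Homo sapiens) (on this read-out lower numbers stand for stronger inhibition and higher numbers for weaker inhibition), the lower of the two numbers measured so far. Within the data shown here, its nearest neighbour is compound 1 `CN(C)S(=O)(=O)NC[C@@H]1CCCc2cc(S(=O)(=O)c3cccc(F)c3)ccc21`, which in this assay gives 2 nM; the only measured step, a 3.2-fold lower number from compound 1 to compound 2 (0.50 log units; beyond the scatter), came from exchanging this side chain. Compound 3 `CN(C)C(=O)NC[C@@H]1CCCc2cc(S(=O)(=O)c3cccc(F)c3)ccc21` carries a group of 6 heavy atoms (3 carbon, 2 nitrogen, 1 oxygen; no ring) in place of a group of 6 heavy atoms (2 carbon, 3 nitrogen, 1 oxygen; no ring), on a saturated chain carbon bound to a saturated ring carbon. This returns to a side chain resembling that of compound 1, roughly undoing the measured step. For compound 3 a modest rise in the number is therefore expected, a 3.2-fold higher number from compound 2 to compound 3 (0.50 log units; beyond the scatter). Compound 3 is estimated at 2 nM in this assay, within a range from 0.8 nM to 5 nM.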

Compound 3, inhibition constant: 2.51 nM
For compound 3 the middle estimate is 1.3-fold (0.10 log units) below the measured one; the measured number falls inside the stated range.
By their numbers in this assay, from the lowest: compound 2; then compounds 1 and 3 (each within the scatter of the next).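

In this assay the (dimethylcarbamoyl)amino group brings a 4.0-fold higher number from compound 2 to compound 3 (0.60 log units; beyond the scatter) and so the side chain of compound 2 keeps the lowest number of the three. With a 1.3-fold higher number from compound 1 to compound 3 (0.10 log units; within the scatter) dimethylcarbamoyl and dimethylsulfamoyl on the amine nitrogen cannot be told apart in this assay at this position. No measurement here accounts for what sets the side chain of compound 2 apart. Going by these compounds, whether a simple amine or a carboxylic acid on this chain would reach the number of compound 2 remains open, and so does the outcome of a longer chain carrying the dimethylcarbamoyl group.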